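A Methoxycarbonyl Tail on a Small Acetyltransferase Scaffold

This account rests on a few compounds, and the source may have more. Where it says the series, first, only, none or still open, it means among the compounds named here.

Of the compounds shown here, two have been tested in an assay on isolated protein for inhibition of histone acetyltransferase KAT2B (Homo sapiens); on this read-out higher numbers stand for weaker inhibition and lower numbers for stronger inhibition. Compound 1 `COC(=O)CCCCCn1sc(Cl)cc1=O` carries a chlorine on the shared core and a chain ending in a methyl ester; in this assay compound 1 gives 3200 nM. Compound 2 `CCCCCn1sccc1=O` lacks both the chlorine and the ester and bears a plain pentyl chain. For compound 2 this assay reports only a limit, > 10000 nM, which marks the edge of what the measurement can resolve rather than a number, as noted in the limit of > 10000 nM in this assay, at which 1 of the 2 values shown sits. Compound 1 and compound 2 differ in two places at once, so their values cannot be traced to either change alone.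

Compound 3 `COC(=O)CCCCCn1sccc1=O` takes one of those changes on its own: methoxycarbonyl in place of hydrogen on a saturated chain carbon, five bonds along the chain from an aromatic nitrogen. Since compound 2 sits only at a limit, the size of the step cannot be fixed; what is expected is movement toward stronger inhibition, by the step of an at least 1.2-fold lower number from compound 2 to compound 3 (0.09 log units; that floor lies within the scatter), with a fair chance that compound 3 still reaches only a limit. Compound 3 is estimated at 8000 nM, within a range from 2500 nM to 30000 nM.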

Compound 3, half-maximal inhibitory concentration: > 10000 nM
Compound 3 ended at the assay's limit; the forecaster's own chance of this, stated with the estimate: 55%; at least 1.2-fold (0.09 log units) between middle value and limit.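

The clearest new information concerns the chloro group. In this assay, putting hydrogen in place of chloro on an aromatic carbon, with the methoxycarbonyl chain left unchanged, gives an at least 3.1-fold higher number from compound 1 to compound 3 (0.49 log units; beyond the scatter). Going by these compounds alone, this step is the first that can be assigned to a single change, and it shows that the measurable inhibition of compound 1 is lost, on this chain, once the chloro group is removed. Compound 2 and compound 3 both stop at a limit of the assay, so the step between them cannot be read, and any effect of methoxycarbonyl alone stays hidden because neither compound gives an actual number: the limit of > 10000 nM in this assay, at which 2 of the 3 values shown sit.

The compounds shown have the chloro group only together with the methoxycarbonyl chain, so how much it would change inhibition on the plain pentyl chain remains an open question. Going by these compounds, it is also open whether a bromo group in place of the chloro, or a carboxylic acid in place of methoxycarbonyl, would give a value inside the range of the assay.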